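The source may hold more compounds than are shown below. What is called first, only, known or untested is meant among the compounds shown, and "the series" means these compounds.

Measured in a functional assay on THP-1 cells (Homo sapiens) for inhibition, with a stated time of 48 h, tested at 50 uM; on this read-out higher numbers stand for more inhibition of growth at the one concentration tested and lower numbers for less inhibition of growth:
- compound 1 `C=C[C@@](C)(/C=C/c1ccc(OC(=O)CCCCCCCCC)cc1)CCC=C(C)C` gives 52%
- compound 2 `CC[C@](C)(CCCC(C)C)CCc1ccc(O)cc1` gives 58%
- compound 3 `C=C[C@@](C)(/C=C/c1ccc(O)cc1)CC/C=C(/C)C=O` gives 54%

Compound 3 holds the second highest of the three numbers, but it lies within the scatter of both other compounds, so these values give no real ranking.

The next compound is compound 4 `C=C[C@@](C)(/C=C/c1ccc(O)cc1)CCC1OC1(C)C`, which carries 3,3-dimethyloxiran-2-yl in place of 2-formylprop-1-en-1-yl on a saturated chain carbon, three bonds along the chain from two double-bonded chain carbons. The counted difference reads 3,3-dimethyloxiran-2-yl in place of 2-formylprop-1-en-1-yl on a saturated chain carbon, three bonds along the chain from two double-bonded chain carbons and leaves the phenol end of compound 3 untouched.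

Going by the values given here, no measured pair differs in one place only, so no direct step is available as a guide, and no measured compound carries the 3,3-dimethyloxiran-2-yl group. The only support is indirect: compound 1 (52%) and compound 2 (58%) differ from compound 3 in more than one place, yet their values remain within the scatter of its value.

No step beyond the scatter is expected, in either direction. The estimated a number 2 percentage points lower from compound 3 to compound 4 (within the scatter) is therefore small and carries no firm direction. For compound 4 the expected value is 52% with an estimated range from 40% to 64% in the coming measurement.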

Compound 4, percent growth inhibition at one concentration: 52%
Estimate against measurement, compound 4: no gap at the digits printed; the range from low to high includes it.
By their numbers in this assay, from the lowest: compounds 1, 4, 3 and 2 (each within the scatter of the next).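

In this assay, going by these compounds alone, the exchange of 2-formylprop-1-en-1-yl for 3,3-dimethyloxiran-2-yl gives the first step that can be read at a single place: a number 2 percentage points lower from compound 3 to compound 4 (within the scatter). On a saturated chain carbon, three bonds along the chain from two double-bonded chain carbons, the two double bonds of the leaving group give way to a three-membered non-aromatic ring with one hetero atom, while the heavy-atom and hydrogen-bond acceptor counts stay the same, and the read-out does not separate the two groups. No available evidence ties this result to any feature of either group.

The compounds shown leave open whether any group at this place can move the read-out beyond the scatter, for instance an amine, a carboxylic acid or a longer chain in place of 3,3-dimethyloxiran-2-yl. Also open, on these data alone, is whether this exchange would read the same way at other concentrations or on other cell types, for every number here comes from a single concentration on one cell line.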